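A few compounds are considered here, and "the series" means these few. Any claim that something is new, unique, unknown or untested is made for them only; others in the source may bear on it.

Compound 1, `CNC(=O)c1cc(Oc2ccc(NC(=O)c3cc(-c4ccc(Cl)cc4)ncn3)cc2F)ccn1`, in a functional assay on MCF7 cells (Homo sapiens) for cytotoxicity, read by MTT assay, with a stated time of 72 h (on this read-out higher numbers stand for weaker inhibition and lower numbers for stronger inhibition), gives > 100000 nM, which is a limit of the assay and not a number.
Compound 2, `CNC(=O)c1cc(Oc2ccc(NC(=O)c3cc(-c4ccc(Cl)cc4)ncn3)cc2)ccn1`, in this assay gives > 100000 nM, again a limit.
Compound 3, `CNC(=O)c1cc(Oc2ccc(NC(=O)c3cc(-c4ccccc4)ncn3)cc2F)ccn1`, in this assay gives 32400 nM.

Compound 3 is the only one of the three with a measured number; the other two sit at the limit of > 100000 nM in this assay, at which 2 of the 3 values shown sit. From compound 1 to compound 3 the change is hydrogen in place of chloro on an aromatic carbon, and the step is an at least 3.0-fold lower number from compound 1 to compound 3 (0.48 log units; beyond the scatter). Compound 2 differs from compound 1 by fluoro in place of hydrogen on an aromatic carbon; the step that the two limits leave unreadable from compound 2 to compound 1. The difference between compound 2 and compound 3 is not broken down here.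

Compound 4, `CNC(=O)c1cc(Oc2ccc(NC(=O)c3cc(-c4ccc(F)cc4)ncn3)cc2F)ccn1`, is not yet measured. It differs from compound 3 by fluoro in place of hydrogen on an aromatic carbon. This is the same kind of change as from compound 2 to compound 1, but not the same: in compound 1 the fluoro sits ortho to a (2-(methylcarbamoyl)pyridin-4-yl)oxy group and meta to a large group, whereas in compound 4 it sits para to a large group on the ring that carried chloro in compound 1. Since chloro at that place gave the step of an at least 3.0-fold lower number from compound 1 to compound 3 (0.48 log units; beyond the scatter) toward the limit, a halogen there is expected to raise the number again, though fluoro need not match chloro; the step expected is a 1.7-fold higher number from compound 3 to compound 4 (0.23 log units; within the scatter). Compound 4 is therefore estimated at 55000 nM in this assay, between 20000 nM and 100000 nM.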

Compound 4, half-maximal inhibitory concentration: > 100000 nM
Compound 4: only a limit was reported; the forecaster's own chance of this, stated with the estimate: 35%; middle value at least 1.8-fold (0.25 log units) away from the limit.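

In this assay, the change from phenyl to 4-fluorophenyl gives an at least 3.0-fold higher number from compound 3 to compound 4 (0.48 log units; beyond the scatter), so on the core of compound 3 the added fluoro goes with weaker inhibition, and the true size of the step may be larger than printed. Among these compounds, the same kind of change, fluoro in place of hydrogen on an aromatic carbon, also links compound 2 to compound 1, but at another place in the molecule, and neither that step nor the one between compound 1 and compound 4 can be read, as both ends of each pair stand at the same limit: the limit of > 100000 nM in this assay, at which 3 of the 4 values shown sit. The series therefore shows the effect of this change in one setting only, and it does not show whether the effect carries over to another core, or how large it would be there.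

With only hydrogen, fluoro and chloro shown on that outer ring, it stays open whether another group in the same place, such as a methoxy group, a nitrile or an amine, would give a lower number than compound 3, at 32400 nM. Also open is what the fluoro on the other ring does when the outer ring carries only hydrogen, a question that needs a compound beyond the four shown.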